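Series notes: piperazine variation on the shared core

The compounds below may be only part of what the source reports. "The series", "measured", "known", "first", "only" and "open" are said of these compounds alone.

Measured so far, in a functional assay on HT-29 cells (Homo sapiens) for cytotoxicity, read by MTT assay, with a stated time of 24 h, tested at 1.6 ug/mL; on this read-out lower numbers stand for a weaker effect and higher numbers for a stronger effect at the one concentration tested:
compound 1, `Cn1c(-c2ccc(NC(=O)CSc3nc4ccccc4s3)cc2)nc(-c2ccccc2)c1-c1ccccc1`, gives 15.3%
compound 2, `Cn1ccnc1SCC(=O)Nc1ccc(-c2nc(-c3ccccc3)c(-c3ccccc3)n2C)cc1`, gives 23.8%
compound 3, `CCN1CCN(CC(=O)Nc2ccc(-c3nc(-c4ccccc4)c(-c4ccccc4)n3C)cc2)CC1`, gives 13.9%

Compound 3 sits at the low end of the three numbers, but both its neighbours lie within the scatter: a number 1.4 percentage points lower from compound 1 to compound 3 (within the scatter) and a number 9.9 percentage points lower from compound 2 to compound 3 (within the scatter). The step to compound 1 from compound 2 is also small, a number 8.5 percentage points higher from compound 1 to compound 2 (within the scatter). Across the three, changing the group on the saturated chain carbon bound to the carbonyl carbon has not moved this assay beyond noise.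

Compound 4, `CN(C)/C=C/N1CCN(CC(=O)Nc2ccc(-c3nc(-c4ccccc4)c(-c4ccccc4)n3C)cc2)CC1`, differs from compound 3 in one place: 2-(dimethylamino)ethenyl in place of ethyl on an amine nitrogen in a ring. Among the measured compounds shown here, no measured step touches the amine nitrogen in the ring, so nothing bears directly on it; the three steps seen are all within the scatter. Compound 4 is therefore expected to stay near compound 3, with an estimated step of a number 1.1 percentage points higher from compound 3 to compound 4 (within the scatter). Compound 4 is estimated at 15%, within 5% to 28%.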

Compound 4, a percentage reported as activity, at one concentration (the size of the read-out at that concentration, not a potency): 8%
For compound 4 the middle estimate is 7 percentage points above the measured one; measured number inside the range.
By their numbers in this assay, from the lowest: compounds 4, 3, 1 and 2 (each within the scatter of the next, the first and the last beyond it).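

At the amine nitrogen in the ring, 2-(dimethylamino)ethenyl in place of ethyl gives a number 5.9 percentage points lower from compound 3 to compound 4 (within the scatter) in this assay, so the larger group is not told apart from ethyl here, and a number 7.3 percentage points lower from compound 1 to compound 4 (within the scatter) also stays within the noise. Only a number 15.8 percentage points lower from compound 2 to compound 4 (beyond the scatter) separates two compounds in this series, yet compound 3 remains within the scatter of compound 2, so this gap cannot be tied to the enamine-bearing group alone. Nothing available explains these numbers.

Going by these compounds, whether an acetyl group, a 2-hydroxyethyl group or a longer alkyl chain on that ring nitrogen would read apart from ethyl stays open. So does whether any of these differences would hold at other concentrations.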